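Moving from trifluoromethyl to fluorine on the phenyl arm

This account rests on a few compounds, and the source may have more. Where it says the series, first, only, none or still open, it means among the compounds named here.

Measured compounds:
Compound 1, `N=C(NCCCc1c[nH]cn1)NCCC(c1ccccc1)c1ccccn1`, in a functional assay on ileum for antagonist activity at histamine H1 receptor (Cavia porcellus) (on this read-out higher numbers stand for weaker binding and lower numbers for tighter binding), compound 1 gives 97.7 nM.
Compound 2, `N=C(NCCCc1c[nH]cn1)NCCC(c1ccc(Br)cc1)c1ccccn1`, in this assay compound 2 gives 120 nM.
Compound 3, `N=C(NCCCc1c[nH]cn1)NCCC(c1ccc(C(F)(F)F)cc1)c1ccccn1`, in this assay compound 3 gives 282 nM.

Compound 3 has the highest number of the three in this assay; its steps to compound 2 and to compound 1 both lie beyond the scatter, so it is the weakest of the set. Compound 4, `N=C(NCCCc1c[nH]cn1)NCCC(c1cccc(F)c1)c1ccccn1`, is the next compound, and it differs from compound 3 by 3-fluorophenyl in place of 4-(trifluoromethyl)phenyl on a saturated chain carbon bound to an aromatic carbon and a saturated chain carbon.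

Among the measured compounds shown here, three measured steps bear on this change. Adding trifluoromethyl to the phenyl ring gave a 2.9-fold higher number from compound 1 to compound 3 (0.46 log units; beyond the scatter), and exchanging bromo for trifluoromethyl gave a 2.4-fold higher number from compound 2 to compound 3 (0.37 log units; beyond the scatter), whereas adding bromo gave a 1.2-fold higher number from compound 1 to compound 2 (0.09 log units; within the scatter). Removing the trifluoromethyl group is therefore expected to bring the number back down toward that of compound 1, and the fluorine is expected, by analogy with the bromo step, to change little. The estimated step is a 2.4-fold lower number from compound 3 to compound 4 (0.37 log units; beyond the scatter), toward tighter binding. Compound 4 is accordingly expected to give about 120 nM in this assay, within a range of 60 nM to 250 nM.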

Compound 4, dissociation constant: 158 nM
The estimate for compound 4 lay 1.3-fold (0.12 log units) below the measured number; low and high end bracket the measured number.
By their numbers in this assay, from the lowest: compounds 1, 2, 4 and 3 (each within the scatter of the next, the first and the last beyond it).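

In this assay, 3-fluorophenyl in place of 4-(trifluoromethyl)phenyl gives a 1.8-fold lower number from compound 3 to compound 4 (0.25 log units; within the scatter), so at this position the exchange cannot be told apart from no change. The same holds for the exchange of 4-bromophenyl, with a 1.3-fold higher number from compound 2 to compound 4 (0.12 log units; within the scatter), and for the fluoro group added to the phenyl arm of the core, with a 1.6-fold higher number from compound 1 to compound 4 (0.21 log units; within the scatter), which leaves fluoro, like bromo, without a step beyond the scatter from the unsubstituted compound 1. Compound 4 thus stands within the scatter of compound 1, compound 2 and compound 3 alike, so the distance of compound 3 from compound 1 and compound 2 is the only separation left in the set, and nothing on hand accounts for it.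

Since 3-fluorophenyl and 4-(trifluoromethyl)phenyl differ both in the group and in where it sits on the ring, the step cannot show which of the two counts. From the compounds shown here alone, how a methoxy group, a nitrile or an amine on the phenyl arm would read in this assay remains open.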